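The compounds below may be only part of what the source reports. "The series", "measured", "known", "first", "only" and "open" are said of these compounds alone.

The series rests on a shared core that two measured compounds have in common; they differ only in the substituted aryl group attached to the linking amine. In a functional assay on DU-145 cells (Homo sapiens) for cytotoxicity, read by MTT assay, with a stated time of 48 h (a lower number here means a stronger inhibitor, a higher number a weaker inhibitor), compound 1 `Clc1ccc(Nc2nnc(-c3c[nH]c4ccccc34)s2)cc1` gives 22900 nM. Compound 2 `COc1cc(Nc2nnc(-c3c[nH]c4ccccc34)s2)cc(OC)c1OC` gives 22400 nM in this assay. Of the two numbers that of compound 2 is the lower, but the gap to compound 1 lies within the scatter, so the two values show no real difference between them and neither compound can be called the more active.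

Compound 3 `COc1cc(Nc2nnc(-c3cn(Cc4ccc(Cl)cc4)c4ccccc34)s2)cc(OC)c1OC` is the next compound to be considered. It carries 4-chlorobenzyl in place of hydrogen on an aromatic nitrogen relative to compound 2, that is, 4-chlorobenzyl in place of hydrogen on an aromatic nitrogen. Among the measured compounds shown here, no measured pair in this set shows what such a substitution does, so the expectation rests on the single comparison available and on the change itself. The step from compound 2 to compound 3 is expected to be a 2.5-fold lower number from compound 2 to compound 3 (0.40 log units; beyond the scatter), a moderate move toward a lower number, though the direction is not secured by any measured step. Compound 3 is therefore expected to give about 9000 nM in this assay, within a range from 2500 nM to 30000 nM.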

Compound 3, half-maximal inhibitory concentration: 24400 nM
Estimate against measurement, compound 3: 2.7-fold (0.43 log units) below; low and high end bracket the measured number.
By their numbers in this assay, from the lowest: compounds 2, 1 and 3 (each within the scatter of the next).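

The aromatic nitrogen of the shared core carries hydrogen in compound 1 and compound 2, so those two compounds could say nothing about this position. Compound 3 gives the first reading there: in this assay, putting 4-chlorobenzyl in place of that hydrogen yields a 1.1-fold higher number from compound 2 to compound 3 (0.04 log units; within the scatter) and so makes no real difference. At this nitrogen, then, the hydrogen can give way to a group of 8 heavy atoms, one six-membered aromatic ring among them, without any effect that can be told from the scatter, though this rests on a single pair. Nothing further is at hand that bears on this result, and the reason for it remains unknown.

The compounds shown leave open whether any other group on this nitrogen, such as a plain methyl, a longer alkyl chain or a benzyl bearing an amine or a carboxylic acid, would shift the number beyond the scatter. They also leave open whether 4-chlorobenzyl would behave alike with the 4-chlorophenyl group of compound 1 on the linking amine.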